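Two Isomeric Side Chains on a Shared Core

This account rests on a few compounds, and the source may have more. Where it says the series, first, only, none or still open, it means among the compounds named here.

Measured in a functional assay on DU-145 cells (Homo sapiens) for cytotoxicity, read by MTT assay; a higher number here means a weaker inhibitor, a lower number a stronger inhibitor:
- compound 1 `CC(C)=CC[C@@H](OC(=O)c1ccco1)C1=CC(=O)c2c(O)ccc(O)c2C1=O`: > 100000 nM, a limit of the assay
- compound 2 `CC(C)=CC[C@@H](OC(=O)CC(O)c1ccccc1)C1=CC(=O)c2c(O)ccc(O)c2C1=O`: 17000 nM
- compound 3 `CCC(CO[C@H](CC=C(C)C)C1=CC(=O)c2c(O)ccc(O)c2C1=O)OC(C)=O`: 25400 nM

Compound 3 lies within the scatter of compound 2, and the only other result is the limit of compound 1. Compound 4 `CC[C@@](C)(O)CC(=O)O[C@H](CC=C(C)C)C1=CC(=O)c2c(O)ccc(O)c2C1=O` has (2-hydroxy-2-methylbutyl)carbonyl in place of 2-acetoxybutyl on an oxygen on a saturated carbon. The two have the same atoms, joined differently.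

Within the data shown here, no measured step covers this exact change. Among the measured compounds shown here, two steps bear on it, and both start from a limit, so they fix only a minimum size: an at least 5.8-fold lower number from compound 1 to compound 2 (0.76 log units; beyond the scatter) and an at least 3.9-fold lower number from compound 1 to compound 3 (0.59 log units; beyond the scatter). Compound 2, with 2-hydroxy-2-phenylethyl on a carbonyl carbon, gives 17000 nM, which suggests that compound 4 should stay close to compound 3. No change beyond the scatter is therefore expected, and the expected step is a 1.3-fold lower number from compound 3 to compound 4 (0.10 log units; within the scatter). For compound 4 the estimated value is 20000 nM, with an expected range from 6000 nM to 60000 nM.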

Compound 4, half-maximal inhibitory concentration: 12700 nM
The estimate for compound 4 lay 1.6-fold (0.20 log units) above the measured number; the measured number falls inside the stated range.
By their numbers in this assay, from the lowest: compounds 4, 2 and 3 (each within the scatter of the next). At a limit, above all of these: compound 1.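

In this assay, exchanging 2-acetoxybutyl for (2-hydroxy-2-methylbutyl)carbonyl, two groups made of the same atoms, gives a 2.0-fold lower number from compound 3 to compound 4 (0.30 log units; within the scatter), so this rearrangement on the oxygen does not move the number beyond the scatter. Replacing hydroxy(phenyl)methyl with 1-hydroxy-1-methylpropyl gives a 1.3-fold lower number from compound 2 to compound 4 (0.13 log units; within the scatter), so compound 4 stays level with compound 2 without a phenyl ring in its side chain. The furan-2-yl ester stands apart, with an at least 7.8-fold lower number from compound 1 to compound 4 (0.89 log units; beyond the scatter), a step that starts from a limit of the assay: the limit of > 100000 nM in this assay, at which 1 of the 4 values shown sits.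

The compounds shown do not tell which feature of the side chains of compounds 2, 3 and 4 separates them from the furan-2-yl group of compound 1. Going by these compounds, whether an amine, a carboxylic acid or a longer chain at this position would shift the number beyond the scatter stays open.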